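The compounds below may be only part of what the source reports. "The series", "measured", "known", "first", "only" and "open" are said of these compounds alone.

For the measured compounds named here, compound 1 `Fc1ccc(C(SCCNC2CCN(Cc3cc4ccccc4[nH]3)CC2)c2ccc(F)cc2)cc1` is one of two compounds measured in an assay on membranes from striatum (strain Sprague-Dawley) for displacement of a labelled ligand from sodium-dependent dopamine transporter (Rattus norvegicus), read by scintillation counting, with a stated time of 120 min; a lower number here means a stronger inhibitor, a higher number a weaker inhibitor. In this assay compound 1 gives 179 nM, the lowest of the two numbers; the other measured compound, compound 2 `CC(C)(C)CN1CCC(NCC[S+]([O-])C(c2ccc(F)cc2)c2ccc(F)cc2)CC1`, gives 431 nM, a value that stands beyond the usual scatter from that of compound 1. Compound 3 `O=C(c1ccc(F)cc1F)N1CCC(NCCSC(c2ccc(F)cc2)c2ccc(F)cc2)CC1` has not been measured. It differs from compound 1 in one place: (2,4-difluorophenyl)carbonyl in place of (1H-indol-2-yl)methyl on an amine nitrogen in a ring. Going by the values given here, no pair of measured compounds shows this kind of change, so no measured step can guide the size of its effect; the two values at hand only show that a different group on that ring nitrogen goes together with a weaker number for compound 2 than for compound 1. Compound 3 is therefore expected to sit at or somewhat above the value of compound 1, with a step from compound 1 to compound 3 estimated as a 2.8-fold higher number from compound 1 to compound 3 (0.45 log units; beyond the scatter) and wide uncertainty. The estimate for compound 3 in this assay is 500 nM, with a range from 150 nM to 1800 nM.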

Compound 3, inhibition constant: 30 nM
Beside the measured number, compound 3's estimate is 17-fold (1.22 log units) above it, outside the stated range (below it).
By their numbers in this assay, from the lowest: compound 3; then compound 1; then compound 2.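

For the compounds shown here, on the amine nitrogen of the six-membered non-aromatic ring, putting (2,4-difluorophenyl)carbonyl in place of (1H-indol-2-yl)methyl gives, in this assay, a 6.0-fold lower number from compound 1 to compound 3 (0.78 log units; beyond the scatter), the first step that can be read at this position. The lower number comes with the loss of the five-membered aromatic ring and the hydrogen-bond donor, and the gain of a carbonyl, so in this pair neither that ring nor that donor is required for the stronger inhibition. Nothing available explains why this change goes with the lower number.

Because the change alters several features at once, this one step cannot separate the contribution of the carbonyl from that of the two fluorines. A plain benzoyl group or a (2,4-difluorophenyl)methyl group on the same nitrogen would tell them apart.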